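Leucine-derived amide replaces aminocyclohexyl amide on shared core

The source may report more compounds than this note shows. Statements on the series, on what has been measured and on what is new or still open speak of the compounds shown alone.

Measured compounds:
compound 1, `N[C@H](C(=O)Nc1cc2cc[nH]c(=O)c2cc1Cl)C1CCCCC1`, 180 nM
compound 2, `N[C@H]1CC[C@H](C(=O)Nc2cc3cc[nH]c(=O)c3cc2Cl)CC1`, "not determined" (no result reported)

Compound 1 carries a cyclohexyl-bearing amino acid amide on the shared core and, in a functional assay (aorta) with Rattus norvegicus as the target (a higher number here means that more compound is needed for the effect, a lower number that less compound is needed), compound 1 gives 180 nM. Compound 2 carries a 4-aminocyclohexyl amide on the same core, but in this assay compound 2 gives "not determined" (no result reported), so compound 2 stands nowhere on the numbers shown and no step from it can be measured.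

Compound 3, `CC(C)C[C@@H](N)C(=O)Nc1cc2cc[nH]c(=O)c2cc1Cl`, differs from compound 2 in one place: 1-amino-3-methylbutyl in place of 4-aminocyclohexyl on a carbonyl carbon. For the measured compounds named here, with no value for compound 2, neither size nor direction of the step into compound 3 can be anchored; the only reference is compound 1, which shares the core and an amino acid amide with compound 3. Compound 3 is therefore expected to lie near compound 1, at an estimated 300 nM, within a range of 80 nM to 1200 nM.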

Compound 3, half-maximal effective concentration: 700 nM
For compound 3 the middle estimate is 2.3-fold (0.37 log units) below the measured one, within the range that was stated.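

For the compounds shown here, compound 2 has no single number in this assay, so no step from compound 2 to compound 3 can be read. The compounds shown leave open how 4-aminocyclohexyl and 1-amino-3-methylbutyl compare on the carbonyl carbon. No evidence shown bears on this result.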